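A few compounds are considered here, and "the series" means these few. Any claim that something is new, unique, unknown or untested is made for them only; others in the source may bear on it.

Of the compounds shown here, three sharing one core have been tested in a functional assay on UACC-62 cells (Homo sapiens) for inhibition, read by sulforhodamine B assay, with a stated time of 48 h; on this read-out higher numbers stand for weaker inhibition of growth and lower numbers for stronger inhibition of growth. Compound 1 `COc1cc(-c2cc(/C=C/C(=O)c3ccc(N)cc3)[nH]n2)cc(OC)c1OC` gives 1700 nM. Compound 2 `COc1ccc(-c2cc(/C=C/C(=O)c3ccc(OC)c(OC)c3)[nH]n2)cc1` gives 1650 nM, a number within the scatter of that of compound 1. Compound 3 `COc1cc(-c2cc(/C=C/C(=O)c3ccc(Cl)c(Cl)c3)[nH]n2)cc(OC)c1OC` gives 18800 nM. Compound 1 therefore stands second highest of the three numbers, nearest to compound 2 and furthest from compound 3. Within the data shown here, the only step measured in one place is an 11-fold higher number from compound 1 to compound 3 (1.04 log units; beyond the scatter), a change on the carbonyl side of the core.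

Compound 4 `COc1ccc(-c2cc(/C=C/C(=O)c3ccc(N)cc3)[nH]n2)cc1OC` differs from compound 1 by hydrogen in place of methoxy on an aromatic carbon. Among the measured compounds shown here, this change sits on the other ring of the core, so the step from compound 1 to compound 3 does not bear on it, and no measured step does. Compound 2 differs from compound 1 in more than one place, and its value and that of compound 1 lie within the scatter of each other. With nothing pointing to a shift, no step beyond the scatter is expected, that is a 1.2-fold higher number from compound 1 to compound 4 (0.07 log units; within the scatter). Compound 4 is estimated at 2000 nM, within a range from 800 nM to 5000 nM.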

Compound 4, concentration for 50% growth inhibition: 3110 nM
Beside the measured number, compound 4's estimate is 1.6-fold (0.19 log units) below it, and the stated range covers the measured number.
By their numbers in this assay, from the lowest: compounds 2, 1 and 4 (each within the scatter of the next); then compound 3.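

In this assay, the methoxy group that is ortho to a methoxy group and meta to a large group can give way to hydrogen with only a small shift: a 1.8-fold higher number from compound 1 to compound 4 (0.26 log units; within the scatter). Among these compounds, this is the first step measured in one place on this side of the core, and it shows that, with the 4-aminophenyl group held fixed, this single methoxy group is not needed to keep the number within the scatter of compound 1, unlike the change on the carbonyl side, an 11-fold higher number from compound 1 to compound 3 (1.04 log units; beyond the scatter). No outside data bear on this small step, so the compounds give no explanation for it.

Only hydrogen and methoxy are shown at this position, so it remains open whether a hydroxyl, an amine or a longer alkoxy chain there would shift the number beyond the scatter. From the compounds shown here alone, it is also open whether the same swap would stay this quiet with 3,4-dichlorophenyl on the carbonyl.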